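Ester to alcohol on a piperidine side chain

The source may report more compounds than this note shows. Statements on the series, on what has been measured and on what is new or still open speak of the compounds shown alone.

Measured compounds:
- compound 1, `COC(=O)C[C@@H]1C[C@@H](O)[C@H](C)[C@H](c2ccccc2)N1`: 5400 nM
- compound 2, `COC(=O)C[C@H]1C[C@H](O)[C@@H](C)[C@@H](c2ccc(OC)cc2)N1`: 5100 nM
- compound 3, `C[C@H]1[C@H](O)C[C@@H](CCO)N[C@H]1c1ccccc1`: 39800 nM

All three were tested in a functional assay on MCF7 cells (Homo sapiens) for cytotoxicity, read by MTT assay; a lower number here means a stronger inhibitor, a higher number a weaker inhibitor. Compound 1 and compound 2 share the same side chain but differ in their cores; that difference between the two cores is not broken down here. Their values lie within the scatter of each other, so no order can be drawn between them.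

Compound 3 is compound 1 with hydroxymethyl in place of methoxycarbonyl on a saturated chain carbon bound to a saturated ring carbon. This change gave a 7.4-fold higher number from compound 1 to compound 3 (0.87 log units; beyond the scatter), a clear weakening.

Compound 4, `COc1ccc([C@H]2N[C@@H](CCO)C[C@H](O)[C@H]2C)cc1`, is not yet measured. It is compound 2 with hydroxymethyl in place of methoxycarbonyl on a saturated chain carbon bound to a saturated ring carbon, the same change at the same place as from compound 1 to compound 3. Because compound 1 showed a 7.4-fold higher number from compound 1 to compound 3 (0.87 log units; beyond the scatter), a step of similar size is expected from compound 2 to compound 4, about a 7.1-fold higher number from compound 2 to compound 4 (0.85 log units; beyond the scatter). On that basis compound 4 is estimated to give around 36000 nM, plausibly between 12000 nM and 100000 nM.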

Compound 4, half-maximal inhibitory concentration: 13700 nM
Compound 4: the middle estimate sits 2.6-fold (0.42 log units) above what was measured; the measured number falls inside the stated range.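

Putting hydroxymethyl in place of methoxycarbonyl also weakened the compound on the second core: in this assay the change gave a 2.7-fold higher number from compound 2 to compound 4 (0.43 log units; beyond the scatter). The direction of the step carried over from one core to the other, but its size did not: the same change on two cores in this assay, a 7.4-fold higher number (0.87 log units; beyond the scatter) from compound 1 to compound 3 and a 2.7-fold higher number (0.43 log units; beyond the scatter) from compound 2 to compound 4, 2.7-fold (0.44 log units) apart, beyond the scatter of two such steps. Within the data shown here, with only two pairs, this shows that the core can affect how much the change costs, but it cannot show which difference between the cores sets the size, or whether the same direction would hold on a third core.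

The compounds shown leave open how other groups in this place would behave on either core, such as a carboxylic acid, an amide or an amine. They also leave open whether a longer chain ending in the same alcohol would give a larger or smaller step than 2-hydroxyethyl does in this assay.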